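Replacing a tetrazole with a thiadiazole on the aryl ring

The compounds below may be only part of what the source reports. "The series", "measured", "known", "first", "only" and "open" are said of these compounds alone.

Measured compounds:
compound 1 `CCC(C)(C)Cc1c[nH]c(CCc2ccc(-n3ncnn3)cc2)n1`: 422 nM
compound 2 `CCC(C)(C)Cc1c[nH]c(CCc2ccc(-c3cccc(N)n3)cc2)n1`: 37 nM

Of the compounds shown here, two sharing one core have been measured in a functional assay on HEK293 cells for agonist activity at Bombesin receptor subtype-3 (Homo sapiens), read by luminescence and calcium flux, with a stated time of 10 min; on this read-out higher numbers stand for an effect only at larger amounts of compound and lower numbers for an effect already at smaller amounts. Compound 1 gives 422 nM, and compound 2 gives 37 nM. Going by the values given here, compound 1 therefore holds the highest of the two numbers; its only neighbour is compound 2, reached by an 11-fold lower number from compound 1 to compound 2 (1.06 log units; beyond the scatter), a large step that comes from putting 6-aminopyridin-2-yl in place of 2H-tetrazol-2-yl on an aromatic carbon.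

Compound 3 `CCC(C)(C)Cc1c[nH]c(CCc2ccc(-c3csnn3)cc2)n1` has not yet been measured in this assay. It differs from compound 1 in one place: 1,2,3-thiadiazol-4-yl in place of 2H-tetrazol-2-yl on an aromatic carbon. Among the compounds with values here, no measured step shows this particular exchange. Within the data shown here, the only measured step, an 11-fold lower number from compound 1 to compound 2 (1.06 log units; beyond the scatter), replaces the same 2H-tetrazol-2-yl but with a six-membered, amine-bearing group, so it speaks to that group rather than to 1,2,3-thiadiazol-4-yl, which keeps a five-membered aromatic ring of similar size. For compound 3 the estimated step is therefore a 1.4-fold lower number from compound 1 to compound 3 (0.15 log units; within the scatter), close to no change beyond the scatter, with a slight lean toward a lower number. The estimate for compound 3 in this assay is 300 nM, with a range from 80 nM to 1200 nM.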

Compound 3, half-maximal effective concentration: 538 nM
Compound 3: middle estimate off by 1.8-fold (0.25 log units), on the low side; measured number inside the range.
By their numbers in this assay, from the lowest: compound 2; then compounds 1 and 3 (each within the scatter of the next).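

In this assay, putting 1,2,3-thiadiazol-4-yl in place of 2H-tetrazol-2-yl gives a 1.3-fold higher number from compound 1 to compound 3 (0.11 log units; within the scatter), so at this place the two five-membered aromatic rings cannot be told apart, even though their hetero atoms differ in number and kind. Set against the 6-aminopyridin-2-yl group, the same thiadiazole gives a 15-fold higher number from compound 2 to compound 3 (1.16 log units; beyond the scatter), which means that the low number of compound 2 now stands apart from two different five-membered rings rather than from the tetrazole alone. Across these three compounds, only the six-membered, amine-bearing group reaches the lower number, and neither five-membered ring goes against that, though three compounds are a narrow base for any pattern.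

The compounds shown leave open whether the low number of compound 2 belongs to its amine or to its six-membered ring, a question that a plain pyridin-2-yl group or an amine carried on a five-membered ring such as a thiazole would separate. Nothing given here offers an explanation for why the two five-membered rings read alike or why the aminopyridine differs from them.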